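The source may hold more compounds than are shown below. What is called first, only, known or untested is meant among the compounds shown, and "the series" means these compounds.

Compound 3, `CCCCC1(O)C(=O)Nc2ccc(Nc3ccc(Cl)cc3)cc21`, and compound 1, `CCCCC1(O)C(=O)Nc2ccc(Nc3ccc(F)cc3)cc21`, share a core that differs only by chloro in place of fluoro on an aromatic carbon. In a functional assay on NCI-H460 cells (Homo sapiens) for antiproliferative activity, read by MTT assay, with a stated time of 48 h (on this read-out lower numbers stand for stronger inhibition and higher numbers for weaker inhibition), compound 1 gives 32500 nM, and compound 3 gives 24400 nM, two values that sit within the usual scatter of each other. Compound 2, `CC(C)CCC1(O)C(=O)Nc2ccc(Nc3ccc(F)cc3)cc21`, carries methyl in place of hydrogen on a saturated chain carbon bound to two saturated chain carbons on the core of compound 1; in this assay compound 2 gives 16800 nM, so that the step of a 1.9-fold lower number from compound 1 to compound 2 (0.29 log units; within the scatter) stays within the scatter as well.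

Compound 4, `CCCCCC1(O)C(=O)Nc2ccc(Nc3ccc(Cl)cc3)cc21`, has not been measured in this assay. It differs from compound 3 by methyl in place of hydrogen on a saturated chain carbon, four bonds along the chain from a saturated ring carbon. Among the measured compounds shown here, this is the same kind of change as the one from compound 1 to compound 2, though not the same: there the methyl enters on a saturated chain carbon bound to two saturated chain carbons, whereas here it enters on a saturated chain carbon four bonds along the chain from a saturated ring carbon. Because the earlier step of a 1.9-fold lower number from compound 1 to compound 2 (0.29 log units; within the scatter) was small, the step from compound 3 to compound 4 is estimated at a 1.4-fold lower number from compound 3 to compound 4 (0.16 log units; within the scatter). Compound 4 is therefore expected to give about 17000 nM, between 8000 nM and 36000 nM, in this assay.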

Compound 4, half-maximal inhibitory concentration: 40800 nM
Estimate against measurement, compound 4: 2.4-fold (0.38 log units) below; the measured number lies above the stated range.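

Taken alone, a 1.7-fold higher number from compound 3 to compound 4 (0.22 log units; within the scatter) stays within the scatter in this assay, yet set beside the earlier step, the change does not carry over unchanged from one core to the other: the same change on two cores in this assay, a 1.9-fold lower number (0.29 log units; within the scatter) from compound 1 to compound 2 and a 1.7-fold higher number (0.22 log units; within the scatter) from compound 3 to compound 4, 3.2-fold (0.51 log units) apart, beyond the scatter of two such steps.

This does not show that the core alone sets the size or direction of the step, since the methyl enters at a different place in each pair: on a saturated chain carbon bound to two saturated chain carbons in one, and four bonds along the chain from a saturated ring carbon in the other. With one pair on each core, and each step within the scatter on its own, the compounds give no rule for either core.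

The compounds shown leave open whether the methyl would give matching steps on the two cores if it entered at the same place. They also leave open how a longer chain, or an amine in place of the chain, would read in this assay.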